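The source may report more compounds than this note shows. Statements on the series, on what has been measured and on what is new or still open speak of the compounds shown alone.

Values in a functional assay on MDA-N cells (Homo sapiens) for antiproliferative activity (on this read-out higher numbers stand for weaker inhibition of growth and lower numbers for stronger inhibition of growth), for the measured compounds:

compound 1 `Cc1ccc2c(O)cc(-c3cccc(Cl)c3)nc2n1` gives > 100000 nM
compound 2 `Oc1cc(-c2ccc3ccccc3c2)nc2ncccc12` gives 1660 nM
compound 3 `Cc1cc(C)c2c(O)cc(-c3cccc(Cl)c3)nc2n1` gives 19.1 nM

The value of compound 1 is a limit, not a number (the limit of > 100000 nM in this assay, at which 1 of the 3 values shown sits). One change is measured: methyl in place of hydrogen on an aromatic carbon, which gives an at least 5200-fold lower number from compound 1 to compound 3 (3.71 log units; beyond the scatter). The difference between the cores of compound 1 and compound 2 is not broken down here.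

Compound 4 `Cc1cnc2nc(-c3ccc4ccccc4c3)cc(O)c2c1` carries the same kind of change against compound 2: methyl in place of hydrogen on an aromatic carbon. The surroundings differ: in compound 3 the methyl sits ortho to a fused ring, meta to a methyl group and opposite the ring nitrogen; in compound 4 it sits two atoms from the ring nitrogen and para to a fused ring. Since the measured step rests on a limit of > 100000 nM in this assay, at which 1 of the 3 values shown sits, and on a different place, a smaller step is expected from compound 2 to compound 4 in this assay, a 5.5-fold lower number from compound 2 to compound 4 (0.74 log units; beyond the scatter). Compound 4 is expected to give about 300 nM, between 50 nM and 1500 nM.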

Compound 4, concentration for 50% growth inhibition: 132 nM
For compound 4 the middle estimate is 2.3-fold (0.36 log units) above the measured one; the measured number falls inside the stated range.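

In this assay, methyl in place of hydrogen on an aromatic carbon again gives a lower number, a 13-fold lower number from compound 2 to compound 4 (1.10 log units; beyond the scatter), so the direction is shared by both cores, but the size does not carry from one core to the other: the same change on two cores in this assay, an at least 5200-fold lower number (3.71 log units; beyond the scatter) from compound 1 to compound 3 and a 13-fold lower number (1.10 log units; beyond the scatter) from compound 2 to compound 4, at least 410-fold (2.61 log units) apart, beyond the scatter of two such steps
The value of compound 1 is a limit, so the first step has no exact size: the limit of > 100000 nM in this assay, at which 1 of the 4 values shown sits.
The two steps differ in both core and place, so these compounds do not show which of the two sets the size of the step.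

Still open, from the compounds shown here alone, is whether an ethyl group, a methoxy group or an amine on the carbon two atoms from the ring nitrogen would give a number like that of compound 4.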